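From a 3-ethylphenyl to a 3,5-dichlorophenyl amide

The compounds below may be only part of what the source reports. "The series", "measured", "known", "first", "only" and "open" are said of these compounds alone.

Compound 1, `O=C(CN1CCC(c2cccc[n+]2[O-])CC1)Nc1cccc(Cl)c1`, gives 76% in a functional assay on HEK293 cells for agonist activity at D(4) dopamine receptor (Homo sapiens), read by FLIPR; a lower number here means a smaller maximal response, a higher number a larger maximal response.
Compound 2, `Cc1cc(F)ccc1NC(=O)CN1CCC(c2cccc[n+]2[O-])CC1`, gives 84% in this assay.
Compound 3, `CCc1cccc(NC(=O)CN2CCC(c3cccc[n+]3[O-])CC2)c1`, gives 62% in this assay.

Among these three, compound 3 gives the lowest maximal response, and its gaps to compound 1 and to compound 2 are both beyond the scatter. Compound 4, `O=C(CN1CCC(c2cccc[n+]2[O-])CC1)Nc1cc(Cl)cc(Cl)c1`, shares the core and differs from compound 3 only at the amide-type nitrogen: 3,5-dichlorophenyl in place of 3-ethylphenyl on an amide-type nitrogen. Among the compounds with values here, the step that bears most directly on this change is a number 14 percentage points lower from compound 1 to compound 3 (beyond the scatter), a modest fall when ethyl replaced chloro; compound 4 carries chloro at that place again, while its further chloro has no counterpart among the measured compounds. The other steps, a number 8 percentage points higher from compound 1 to compound 2 (within the scatter) and a number 22 percentage points lower from compound 2 to compound 3 (beyond the scatter), concern a different aryl group and say little about an added chloro. Undoing the ethyl-for-chloro exchange points to a rise in this assay roughly back to the level of compound 1, so compound 4 is expected to give 74%, between 58% and 90%. This amounts to an expected step of a number 12 percentage points higher from compound 3 to compound 4 (beyond the scatter), with the extra chloro leaving the range wide.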

Compound 4, largest response reached (reported as efficacy), in percent of the reference or control that the assay uses: 68%
Beside the measured number, compound 4's estimate is 6 percentage points above it; low and high end bracket the measured number.
By their numbers in this assay, from the lowest: compounds 3, 4, 1 and 2 (each within the scatter of the next, the first and the last beyond it).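

In this assay, a second chloro on the aryl group of the amide brings no change that can be told from the scatter: a number 8 percentage points lower from compound 1 to compound 4 (within the scatter). The 3,5-dichlorophenyl group also cannot be separated from the 3-ethylphenyl group, with a number 6 percentage points higher from compound 3 to compound 4 (within the scatter), although the 3-chlorophenyl and 3-ethylphenyl groups did differ beyond the scatter. The 4-fluoro-2-methylphenyl amide remains clearly apart from the new compound, with a number 16 percentage points lower from compound 2 to compound 4 (beyond the scatter), so the 3,5-dichlorophenyl amide joins compound 1 and compound 3 in sitting under compound 2 or close to them.

No evidence is available to explain these numbers. Going by these compounds, it remains open how this response would shift with an amine, a carboxylic acid or a methoxy group in place of the chloro groups on the aryl ring.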